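The source may report more compounds than this note shows. Statements on the series, on what has been measured and on what is new or still open speak of the compounds shown alone.

Going by the values given here, compound 3 `FC(F)(F)Oc1ccc(-c2ccc(-c3ccc(-c4nc5ccccc5[nH]4)cc3)cc2)cc1` carries trifluoromethoxy and gives 100000 nM in a functional assay on A2780 cells (Homo sapiens) for inhibition, read by sulforhodamine B assay (on this read-out higher numbers stand for weaker inhibition of growth and lower numbers for stronger inhibition of growth), as the highest of the three numbers so far. Compound 2 `Fc1ccc(-c2ccc(-c3ccc(-c4nc5ccccc5[nH]4)cc3)cc2)cc1` has fluoro in that place and gives 48200 nM while compound 1 `Cc1ccc2[nH]c(-c3ccc(-c4ccc(-c5ccc(N(C)C)cc5)cc4)cc3)nc2c1` gives 2210 nM with dimethylamino in that place and one added methyl on its core. Compound 4 `CN(C)c1ccc(-c2ccc(-c3ccc(-c4nc5ccccc5[nH]4)cc3)cc2)cc1` is the next to be measured and has dimethylamino in place of trifluoromethoxy on an aromatic carbon. Among the compounds with values here, the one measured step at this place (a 2.1-fold higher number from compound 2 to compound 3 (0.32 log units; beyond the scatter)) is modest and involves no dimethylamino, so it offers little guidance. The better guide is compound 1 (2210 nM), which shares the entering group, although its added methyl keeps the comparison loose. A large step towards a lower number in this assay is therefore expected, and a lower number means stronger inhibition of growth. The expected size is a rough estimate (a 20-fold lower number from compound 3 to compound 4 (1.30 log units; beyond the scatter)). The estimate for compound 4 is 5000 nM (expected range 1500 nM to 25000 nM).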

Compound 4, concentration for 50% growth inhibition: 100000 nM
Beside the measured number, compound 4's estimate is 20-fold (1.30 log units) below it; measured number above the stated range.
By their numbers in this assay, from the lowest: compound 1; then compound 2; then compounds 3 and 4 (each within the scatter of the next).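

In this assay, the new compound shows that dimethylamino on this core brings no gain in growth inhibition over the other groups at this place: the step is no change at the digits printed from compound 3 to compound 4 (within the scatter), and with fluoro as the comparison it is a 2.1-fold higher number from compound 2 to compound 4 (0.32 log units; beyond the scatter). The low number of compound 1 therefore does not come from dimethylamino alone, since removing the single methyl from its core gives a 45-fold higher number from compound 1 to compound 4 (1.66 log units; beyond the scatter). This one small change accounts for the largest step in the set, yet nothing available explains how it acts.

Going by these compounds, the methyl appears only together with dimethylamino, so whether it would lower the number alongside fluoro or trifluoromethoxy stays open. Also open, on these data alone, is how a chloro or methoxy group would behave in the methyl's place, or a primary amine in place of dimethylamino.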